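Trimming a Methoxy Group: From Compound 3 to Compound 4

The source may hold more compounds than are shown below. What is called first, only, known or untested is meant among the compounds shown, and "the series" means these compounds.

Three compounds built on a shared core have been examined in a functional assay on HT-29 cells (Homo sapiens) for inhibition, read by flow cytometry, tested at 10 uM; a higher number here means more inhibition at the concentration tested (going by the name of the read-out), a lower number less inhibition. Compound 1 `O=C(CSc1nc2ccccc2[nH]1)c1ccc(Br)cc1` is reported as "not active" (no number reported), with no number given. Compound 2 `Cc1ccc(C(=O)CSc2nc3ccccc3[nH]2)cc1` gives 40% in this assay. Compound 3 `COc1ccc(C(=O)CSc2nc3ccccc3[nH]2)cc1OC` gives 52.6%, the higher of the two numbers available, and its gap to compound 2 lies beyond the usual scatter.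

Compound 4 `COc1ccc(C(=O)CSc2nc3ccccc3[nH]2)cc1` has not yet been measured. It differs from compound 3 by hydrogen in place of methoxy on an aromatic carbon. Among the measured compounds shown here, no measured pair shows this exact change, so the step is uncertain; a modest decrease, near the edge of the scatter, seems plausible. Compound 4 is expected to give 44%, within a range from 25% to 60%. This corresponds to an expected a number 8.6 percentage points lower from compound 3 to compound 4 (within the scatter).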

Compound 4, a percentage reported as inhibition, at one concentration (the size of the read-out at that concentration, not a potency): 52.6%
Compound 4: middle estimate off by 8.6 percentage points, on the low side; low and high end bracket the measured number.
By their numbers in this assay, from the lowest: compound 2; then compounds 3 and 4 (each within the scatter of the next).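

Hydrogen in place of methoxy, on the carbon ortho to a methoxy group and meta to a large group, gives no change at the digits printed from compound 3 to compound 4 (within the scatter) in this assay, so this second methoxy group is not needed to hold the read-out at this concentration. Methoxy in place of methyl on an aromatic carbon gives a number 12.6 percentage points higher from compound 2 to compound 4 (beyond the scatter), so the single methoxy group keeps the lead over compound 2 that compound 3 showed. Nothing measured here explains either step. As far as these compounds go, whether an amine or a carboxylic acid at the vacated carbon would keep this read-out remains open, as does the effect of a longer chain in place of the remaining methoxy group.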